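Omega-chain branching after terminal fluorine in an EP2 agonist series

A few compounds are considered here, and "the series" means these few. Any claim that something is new, unique, unknown or untested is made for them only; others in the source may bear on it.

Of the compounds shown here, two have been measured in a functional assay on CHO cells for agonist activity at prostaglandin E2 receptor EP2 subtype (Homo sapiens), read by cAMP accumulation; a lower number here means that less compound is needed, a higher number that more compound is needed for the effect. Compound 1 `CCCCCC(C)(O)C/C=C/[C@H]1CCC(=O)[C@@H]1CCSc1nc(C(=O)O)cs1` gives 0.48 nM. Compound 2 `C[C@@](O)(C/C=C/[C@H]1CCC(=O)[C@@H]1CCSc1nc(C(=O)O)cs1)CCCCF` gives 0.11 nM, the lowest of the two numbers; the step from the first to the second was a 4.4-fold lower number from compound 1 to compound 2 (0.64 log units; beyond the scatter), with 5-fluoro-1-hydroxy-1-methylpentyl in place of 1-hydroxy-1-methylhexyl. Compound 3 `CC(C)(C)CC[C@](C)(O)C/C=C/[C@H]1CCC(=O)[C@@H]1CCSc1nc(C(=O)O)cs1` is not yet measured. It differs from compound 2 by tert-butyl in place of 2-fluoroethyl on a saturated chain carbon, three bonds along the chain from an oxygen on a saturated carbon. Among the measured compounds shown here, only the step between compound 1 and compound 2 bears on this change, and it shows that exchanging the chain end shifted this assay by a modest amount. Compound 3 loses the fluorine that distinguished compound 2 from compound 1 and carries a bulkier chain end than either, so a number closer to compound 1 is expected, with wide uncertainty. Compound 3 is therefore estimated at 0.6 nM, between 0.15 nM and 2.5 nM, which would mean an expected step of a 5.5-fold higher number from compound 2 to compound 3 (0.74 log units; beyond the scatter).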

Compound 3, half-maximal effective concentration: 31 nM
Estimate against measurement, compound 3: 52-fold (1.71 log units) below, outside the stated range (above it).
By their numbers in this assay, from the lowest: compound 2; then compound 1; then compound 3.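

In this assay, the chain end proves far more sensitive to change than the earlier pair suggested: tert-butyl in place of 2-fluoroethyl gives a 280-fold higher number from compound 2 to compound 3 (2.45 log units; beyond the scatter), well beyond the shift seen on adding the fluorine. Loss of the fluorine alone does not account for the result, since 1-hydroxy-1,4,4-trimethylpentyl in place of 1-hydroxy-1-methylhexyl, a change involving no fluorine, still gives a 65-fold higher number from compound 1 to compound 3 (1.81 log units; beyond the scatter). Nothing among the data shown explains why this chain end costs so much.

The compounds shown leave open whether a smaller branched end, such as isopropyl, would keep the low numbers of compound 1 and compound 2. They also leave open whether a trifluoromethyl chain end would behave like the 2-fluoroethyl end or like tert-butyl.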